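A few compounds are considered here, and "the series" means these few. Any claim that something is new, unique, unknown or untested is made for them only; others in the source may bear on it.

Three compounds share one core and differ only in the aryl group on an aromatic nitrogen. Compound 1 `COc1ccc(-n2nc(-c3ccc(C(F)(F)F)cc3O)nc2-c2ccccc2O)cc1` carries a 4-methoxyphenyl there; in a functional assay on PC-12 cells (Rattus norvegicus) for cytotoxicity, read by MTT assay, with stated times of 2 h and 24 h, tested at 10 uM (on this read-out higher numbers stand for a stronger effect at the one concentration tested and lower numbers for a weaker effect), compound 1 gives 98.9%. Compound 2 `Oc1cc(C(F)(F)F)ccc1-c1nc(-c2ccccc2O)n(-c2ccccc2Cl)n1` carries a 2-chlorophenyl, and compound 2 gives 102%. Compound 3 `COc1ccccc1-n1nc(-c2ccc(C(F)(F)F)cc2O)nc1-c1ccccc1O` carries a 2-methoxyphenyl, and compound 3 gives 96.2%. The steps between them are all small: a number 3.1 percentage points higher from compound 1 to compound 2 (within the scatter), a number 2.7 percentage points lower from compound 1 to compound 3 (within the scatter) and a number 5.8 percentage points lower from compound 2 to compound 3 (within the scatter). Compound 3 thus sits within the usual scatter of both partners, so none of the three can be set apart from the others.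

Compound 4 `Oc1cc(C(F)(F)F)ccc1-c1nc(-c2ccccc2O)n(-c2cccc(C(F)(F)F)c2)n1` is the next variation at the same place: 3-(trifluoromethyl)phenyl in place of 2-methoxyphenyl on an aromatic nitrogen. Within the data shown here, the steps that bear on this change are those that swapped the aryl group on that nitrogen, and none of them moved the read-out beyond the scatter. The expectation for compound 4 is therefore a step of a number 1.8 percentage points higher from compound 3 to compound 4 (within the scatter) in this assay, which is no change beyond the scatter. Compound 4 is expected to give about 98%, somewhere between 88% and 106%.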

Compound 4, a percentage reported as activity, at one concentration (the size of the read-out at that concentration, not a potency): 99.9%
Beside the measured number, compound 4's estimate is 1.9 percentage points below it; the range from low to high includes it.
By their numbers in this assay, from the lowest: compounds 3, 1, 4 and 2 (each within the scatter of the next).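

In this assay the 3-(trifluoromethyl)phenyl group, which carries fluorine and has no hydrogen-bond acceptor where the 2-methoxyphenyl had one, gives a number 3.7 percentage points higher from compound 3 to compound 4 (within the scatter) and so no real change. Comparisons with the other two aryl groups agree, with a number 2.1 percentage points lower from compound 2 to compound 4 (within the scatter) and a number 1 percentage points higher from compound 1 to compound 4 (within the scatter) leaving all four aryl groups on this nitrogen indistinguishable on this read-out, so a fluorinated group fits the same flat picture as the chloro and methoxy ones. Nothing available here offers a reason for this flat picture.

Every group shown on this nitrogen is a substituted phenyl, so it stays open whether a phenyl bearing an amine or a carboxylic acid, or a plain alkyl chain in place of the ring, would move the number. A single concentration also leaves open whether these compounds differ at other concentrations.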